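This account rests on a few compounds, and the source may have more. Where it says the series, first, only, none or still open, it means among the compounds named here.

Measured so far:
compound 1 `CC1(C)Cc2c(OCc3ccccc3)ccc(C(=O)/C=C/c3cn(-c4ccccc4)nc3-c3ccc([N+](=O)[O-])cc3)c2O1` gives > 100000 nM
compound 2 `CC1(C)Cc2c(ccc(C(=O)/C=C/c3cn(-c4ccccc4)nc3-c3ccc([N+](=O)[O-])cc3)c2OCc2ccccc2)O1` gives 62300 nM

The measurement is a functional assay on PC-3 cells (Homo sapiens) for antiproliferative activity, read by MTT assay, with a stated time of 48 h; on this read-out higher numbers stand for weaker inhibition and lower numbers for stronger inhibition. In this assay compound 1 gives only > 100000 nM, which is a limit of the assay and not a number, so compound 1 stands at the weak end of what the assay can report, at the limit of > 100000 nM in this assay, at which 1 of the 2 values shown sits. Compound 2, which carries the same groups arranged differently on the shared core, gives 62300 nM in this assay, a number rather than a limit. Compound 3 `CC1(C)Cc2c(OCc3ccccc3)ccc(C(=O)/C=C/c3cn(-c4ccccc4)nc3-c3ccc(Cl)cc3)c2O1` has not yet been measured. It differs from compound 1 in one place: chloro in place of nitro on an aromatic carbon. Within the data shown here, no measured pair shows what this exchange does to the read-out, so the expected size of the step is set loosely. For compound 3 the expected step is an at least 1.2-fold lower number from compound 1 to compound 3 (0.09 log units; that floor lies within the scatter), which may well stay within the scatter. The estimate for compound 3 in this assay is 80000 nM, with a range from 30000 nM to 200000 nM, and a real chance that only a limit is reported again.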

Compound 3, half-maximal inhibitory concentration: 8400 nM
Beside the measured number, compound 3's estimate is 9.5-fold (0.98 log units) above it, outside the stated range (below it).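

Replacing the 4-nitrophenyl group with 4-chlorophenyl, with the rest of the molecule unchanged, gives an at least 11-fold lower number from compound 1 to compound 3 (1.07 log units; beyond the scatter) in this assay. This is the first pair shown that differs in one place, and it shows that the group on this aromatic carbon, para to a large group, can by itself move the read-out well beyond the usual scatter; compounds 1 and 2 could not show this, since they differ only in how the same groups are arranged on the shared core. The size of the step is only a floor, because compound 1 gives a limit and not a number: the limit of > 100000 nM in this assay, at which 1 of the 3 values shown sits.

From the compounds shown here alone, whether a methoxy group, an amine or a plain hydrogen at this position would give a lower or a higher number than chloro stays open, and so does whether the change comes from losing nitro or from gaining chloro. Also open, going by these compounds, is whether the same exchange would give a step of similar size on the arrangement found in compound 2, which gives 62300 nM in this assay.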